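Fluoro to bromo on compound 2

The source may hold more compounds than are shown below. What is called first, only, known or untested is meant among the compounds shown, and "the series" means these compounds.

In a functional assay on HepG2 cells (Homo sapiens) for antiproliferative activity, read by MTT assay, with a stated time of 72 h (a higher number here means a weaker inhibitor, a lower number a stronger inhibitor), compound 2 `COc1cc(CCc2ccc(F)cc2)cc(OC)c1O` gives 5470 nM. Compound 1 `COc1cc(CCc2ccccc2)cc(OC)c1O` gives 7830 nM, a number that ordinary repeat scatter cannot separate from that of compound 2. Only compound 3 `COc1ccc(CCc2ccccn2)cc1OC`, at 13800 nM, lies beyond the scatter from compound 2.

The unmeasured compound 4 `COc1cc(CCc2ccc(Br)cc2)cc(OC)c1O` keeps the core of compound 2 and alters a single place: bromo in place of fluoro on an aromatic carbon. In words, this is bromo in place of fluoro on an aromatic carbon, para to a large group.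

Going by the values given here, only one measured step bears on this place: a 1.4-fold lower number from compound 1 to compound 2 (0.16 log units; within the scatter), with fluoro in place of hydrogen, and it stays within the scatter. Among the compounds with values here, that single change gives little to go on, and no compound with bromo has been measured yet. Even so, no shift beyond the scatter is expected. The expected step is a 1.1-fold lower number from compound 2 to compound 4 (0.04 log units; within the scatter). Compound 4 is estimated at 5000 nM, with an expected range from 2400 nM to 10500 nM.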

Compound 4, half-maximal inhibitory concentration: 8490 nM
Estimate against measurement, compound 4: 1.7-fold (0.23 log units) below, within the range that was stated.
By their numbers in this assay, from the lowest: compounds 2, 1, 4 and 3 (each within the scatter of the next, the first and the last beyond it).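

In this assay, this place on the ring now carries three different groups: hydrogen, fluoro and bromo. The swap of fluoro for bromo is a 1.6-fold higher number from compound 2 to compound 4 (0.19 log units; within the scatter), and the swap of hydrogen for bromo is a 1.1-fold higher number from compound 1 to compound 4 (0.04 log units; within the scatter); neither step leaves the scatter, so the assay cannot separate these three groups at this place, para to a large group. No measurement here explains why the numbers lie so close.

The compounds shown carry only hydrogen and two halogens at this place, so they say nothing about how an amine, a carboxylic acid or a longer chain would read there. On these data alone, it also remains open whether a methoxy group at this place would give a number beyond the scatter.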